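The source may report more compounds than this note shows. Statements on the series, on what has been measured and on what is new or still open speak of the compounds shown alone.

Measured so far:
compound 1 `CN(Cc1nc2cc(C(F)(F)F)ccc2nc1-c1ccccc1)c1ccc(F)cc1` gives 5000 nM
compound 2 `COc1cc(N(C)Cc2nc3cc(C(F)(F)F)ccc3nc2-c2ccccc2)cc(OC)c1OC` gives 5000 nM

Both numbers come from an assay on isolated protein for inhibition of Dihydrofolate reductase (Homo sapiens), read by spectrophotometry; a lower number here means a stronger inhibitor, a higher number a weaker inhibitor. In this assay compound 1 gives 5000 nM and compound 2 gives 5000 nM, so compound 1 stands level with compound 2 within the usual scatter, and neither of the two can be called the stronger or the weaker inhibitor on what is shown. Compound 3 `CCN(Cc1nc2cc(C(F)(F)F)ccc2nc1-c1ccccc1)c1ccc(F)cc1` has not yet been measured. It differs from compound 1 by methyl in place of hydrogen on a saturated chain carbon bound to a nitrogen on an aromatic ring. Going by the values given here, no two compounds already measured differ from each other in this way, so there is no measured step of this kind to lean on, and the two numbers at hand give no direction. The expected step in this assay from compound 1 to compound 3 is therefore none beyond the scatter, no change at the digits printed from compound 1 to compound 3 (within the scatter), an expectation resting only on compound 1 at 5000 nM. For compound 3 the estimate in this assay is 5000 nM, expected to fall between 2000 nM and 12000 nM.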

Compound 3, inhibition constant: 3000 nM
Compound 3: the middle estimate sits 1.7-fold (0.22 log units) above what was measured, and the stated range covers the measured number.
By their numbers in this assay, from the lowest: compounds 3, 1 and 2 (each within the scatter of the next).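

In this assay, putting methyl in place of hydrogen on a saturated chain carbon bound to a nitrogen on an aromatic ring, which turns the methyl on that nitrogen into ethyl, gives a 1.7-fold lower number from compound 1 to compound 3 (0.22 log units; within the scatter), the first step read at this position. Going by these compounds alone, the earlier pair offered no step of this kind, and this one shows that a single added carbon here leaves the reading within the normal variation between repeated measurements, so neither compound can be called the better inhibitor and the change has no direction that can be trusted. The result comes with no separate measurement that could explain it, so the data give no reason for the small difference in the numbers.

Going by these compounds, a single small step says little about how much change this position can take, so it remains open whether a longer chain such as propyl, a branched group such as isopropyl, or a chain ending in a hydroxyl or an amine would shift the number beyond the scatter. On these data alone, it is also open whether the same change from methyl to ethyl would behave alike on compound 2, which carries a different group on the aromatic ring.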